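The source may hold more compounds than are shown below. What is called first, only, known or untested is meant among the compounds shown, and "the series" means these compounds.

Compounds measured so far:

Compound 1, `CCN(CC)Cc1cc(C)cc(Nc2nc3ccccc3n2Cc2ccc(C#N)cc2)c1O`, gives 14200 nM.
Compound 2, `CCN(CC)Cc1cc(C)cc(Nc2nc3ccccc3n2Cc2ccc(F)cc2)c1O`, gives 18700 nM.
Compound 3, `CCN(CC)Cc1ccc(Nc2nc3ccccc3n2Cc2ccc(C#N)cc2)cc1O`, gives 39000 nM.

These numbers come from an ADME assay on CHO cells (Cricetulus griseus) for inhibition, read by MTT assay; a higher number here means a weaker inhibitor, a lower number a stronger inhibitor. Compound 1 and compound 2 share one core and differ only in one group: from compound 1 to compound 2 the change is fluoro in place of cyano on an aromatic carbon. That change made a step of a 1.3-fold higher number from compound 1 to compound 2 (0.12 log units; within the scatter), so the two compounds cannot be told apart by this measurement.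

Compound 3 is built on a different core, and the difference between its core and the core of compound 1 is not broken down here. Compound 3 stands highest of the three numbers; compound 2 and compound 1 lie lower by steps beyond the scatter.

Compound 4, `CCN(CC)Cc1ccc(Nc2nc3ccccc3n2Cc2ccc(F)cc2)cc1O`, has not yet been measured in this assay. It differs from compound 3 by fluoro in place of cyano on an aromatic carbon. Among the compounds with values here, this is the same change, made at the same kind of place, as the one from compound 1 to compound 2. Within the data shown here, the only guide to its effect is that earlier step, a 1.3-fold higher number from compound 1 to compound 2 (0.12 log units; within the scatter), which was within the scatter. On that basis the step from compound 3 to compound 4 is expected to be small, about a 1.3-fold higher number from compound 3 to compound 4 (0.11 log units; within the scatter). Compound 4 is therefore expected to give about 50000 nM, most likely between 25000 nM and 100000 nM.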

Compound 4, half-maximal inhibitory concentration: 45800 nM
Beside the measured number, compound 4's estimate is 1.1-fold (0.04 log units) above it; the range from low to high includes it.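

In this assay, replacing cyano with fluoro on the core of compound 3 gives a 1.2-fold higher number from compound 3 to compound 4 (0.07 log units; within the scatter), so this swap cannot be distinguished from no effect on this second core, just as on the first. Carried from one core to the other, the change therefore behaves alike, with no measurable difference between the two steps: the same change on two cores in this assay, a 1.3-fold higher number (0.12 log units; within the scatter) from compound 1 to compound 2 and a 1.2-fold higher number (0.07 log units; within the scatter) from compound 3 to compound 4, 1.1-fold (0.05 log units) apart, within the scatter of two such steps

Within the data shown here, this agreement is limited, however: it rests on only two pairs of compounds, both steps are small enough to be lost in the ordinary variation between repeat measurements, and a small real effect of the swap could remain hidden on either core, while nothing here shows that the same would hold on a third core.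

The compounds shown leave open what other groups would do on that aromatic carbon, para to a large group, since only cyano and fluoro appear there. An amine, a carboxylic acid or a methoxy group in the same place might give a step large enough to read, and only such a step would test whether the two cores truly respond alike.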